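The compounds below may be only part of what the source reports. "The series", "measured", "known", "first", "only" and "open" are said of these compounds alone.

Compound 1 `CN(C)C(=O)c1cc2cnc(Nc3ccc(S(=O)(=O)NCCCCN=C=S)cc3)nc2n1C1CCCC1`: 39.4%
Compound 2 `CN(C)C(=O)c1cc2cnc(Nc3ccc(C(=O)NCCCCN=C=S)cc3)nc2n1C1CCCC1`: 30.2%
Compound 3 `CN(C)C(=O)c1cc2cnc(Nc3ccc(C(=O)NCCCCCCN=C=S)cc3)nc2n1C1CCCC1`: 35.8%

All three were tested in a functional assay on A549 cells (Homo sapiens) for inhibition, read by CCK-8 assay, with a stated time of 72 h, tested at 1 uM; a lower number here means a weaker effect, a higher number a stronger effect of the compound at the concentration tested. Compound 3 stands within the scatter of both neighbours: a number 3.6 percentage points lower from compound 1 to compound 3 (within the scatter) and a number 5.6 percentage points higher from compound 2 to compound 3 (within the scatter), and compound 1 against compound 2 shows the same picture, a number 9.2 percentage points lower from compound 1 to compound 2 (within the scatter). Compound 4 `CN(C)C(=O)c1cc2cnc(Nc3ccc(NC(=O)CCCN=C=S)cc3)nc2n1C1CCCC1` differs from compound 3 by a group of 9 heavy atoms (5 carbon, 2 nitrogen, 1 oxygen, 1 sulfur; no ring) in place of a group of 12 heavy atoms (8 carbon, 2 nitrogen, 1 oxygen, 1 sulfur; no ring), on an aromatic carbon. Going by the values given here, the three measured steps are the only guide, and none of them leaves the scatter; the closest in kind, a number 5.6 percentage points higher from compound 2 to compound 3 (within the scatter), exchanged one chain portion for another and changed little. Compound 4 is therefore expected to remain in the same band, with a step of a number 2.8 percentage points lower from compound 3 to compound 4 (within the scatter) not expected to exceed the scatter. In this assay compound 4 is estimated at 33%, within 20% to 47%.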

Compound 4, a percentage reported as inhibition, at one concentration (the size of the read-out at that concentration, not a potency): 56.1%
Beside the measured number, compound 4's estimate is 23.1 percentage points below it; measured number above the stated range.
By their numbers in this assay, from the lowest: compounds 2, 3 and 1 (each within the scatter of the next); then compound 4.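

In this assay, the group on this aromatic carbon now makes a difference: a number 20.3 percentage points higher from compound 3 to compound 4 (beyond the scatter), a number 25.9 percentage points higher from compound 2 to compound 4 (beyond the scatter) and a number 16.7 percentage points higher from compound 1 to compound 4 (beyond the scatter), whereas the exchanges among compound 1, compound 2 and compound 3 all stayed within the scatter. Compound 4 alone joins the ring through its amide nitrogen, rather than through a carbonyl or sulfonyl, and it also has the smallest group. No available evidence explains the rise.

On these data alone, whether the chain or the reversed amide carries the step stays open. Also open, as far as these compounds go, is whether a longer chain on that amide nitrogen, or an amine at the chain end, would keep it.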